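Amide-substituted imidazole series: cytotoxicity notes on THP-1 cells

The source may hold more compounds than are shown below. What is called first, only, known or untested is meant among the compounds shown, and "the series" means these compounds.

Measured compounds:
- compound 1, `Cn1c(-c2ccccc2)cnc1NC(=O)c1ccccc1`; in a toxicity assay on THP-1 cells (Homo sapiens) for inhibition (on this read-out higher numbers stand for lower toxicity in this test and lower numbers for higher toxicity in this test), compound 1 gives only a limit of the assay, > 100000 nM.
- compound 2, `Cn1c(-c2ccccc2)cnc1NC(=O)c1ccc(Cl)cc1`; in this assay compound 2 gives only a limit, > 100000 nM.
- compound 3, `COc1ccc(-c2cnc(NC(=O)c3ccccc3)n2C)cc1`; in this assay compound 3 gives only a limit, > 100000 nM.

Compound 1 and compound 2 differ by chloro in place of hydrogen on an aromatic carbon. The step between them in this assay is a step that the two limits leave unreadable from compound 1 to compound 2; both values sit at the limit of > 100000 nM in this assay, at which 3 of the 3 values shown sit, so nothing about the size of this step can be read. Compound 1 and compound 3 differ in the core by methoxy in place of hydrogen on an aromatic carbon, and the step that the two limits leave unreadable from compound 1 to compound 3 is likewise hidden by the two limits.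

Compound 4, `COc1ccc(-c2cnc(NC(=O)c3cccc(Cl)c3)n2C)cc1`, is not yet measured. It differs from compound 3 by chloro in place of hydrogen on an aromatic carbon. This is the same kind of change as that from compound 1 to compound 2, though not the same: there the chloro enters para to a large group, here meta to a large group.

Among the measured compounds shown here, every value so far sits at the limit of > 100000 nM in this assay, at which 3 of the 3 values shown sit, and the change to compound 4 is small. Compound 4 is therefore expected to give a step that the limit leaves unreadable from compound 3 to compound 4 in this assay, with the result most likely again a limit rather than a number. The estimate for compound 4 is 120000 nM, with a range from 50000 nM to 300000 nM.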

Compound 4, half-maximal cytotoxic concentration: > 28000 nM
Compound 4 ended at the assay's limit (the forecaster's own chance of this, stated with the estimate: 85%); the middle value does not contradict the limit.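

In this assay compound 4 gives > 28000 nM, a limit of the assay and not a number. Compound 3 gives > 100000 nM, also a limit. The step from compound 3 to compound 4 therefore cannot be read. The compounds shown leave open whether chloro or methoxy in place of hydrogen changes the half-maximal cytotoxic concentration at all; every value shown is a limit.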